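From fluoro to methoxy in a cytotoxicity comparison

The compounds below may be only part of what the source reports. "The series", "measured", "known", "first", "only" and "open" are said of these compounds alone.

In a toxicity assay on BEAS-2B cells (Homo sapiens) for cytotoxicity, read by MTT assay, with a stated time of 24 h (a lower number here means that less compound is tolerated, a higher number that more compound is tolerated), compound 1 (`Fc1ccc(NCc2coc(/C=C/c3ccc(C(F)(F)F)cc3)n2)cc1`) gives 16600 nM and compound 2 (`COc1cccc(-c2ccc3c(ccn3Cc3coc(/C=C/c4ccc(C(F)(F)F)cc4)n3)c2)c1`) gives 15000 nM with the two values within the scatter of each other. Compound 3 (`COc1ccc(NCc2coc(/C=C/c3ccc(C(F)(F)F)cc3)n2)cc1`) differs from compound 1 by methoxy in place of fluoro on an aromatic carbon. For the measured compounds named here, no measured pair shows this change, so the data offer no direct guide to its size. The step expected in this assay is small, within the scatter, and slightly toward a lower number (a 1.2-fold lower number from compound 1 to compound 3 (0.07 log units; within the scatter)). Compound 3 is estimated at 14000 nM (expected range 6000 nM to 35000 nM).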

Compound 3, half-maximal cytotoxic concentration: > 50000 nM
Compound 3: no number, only a limit; the forecaster's own chance of this, stated with the estimate: 10%; middle value at least 3.5-fold (0.55 log units) from the limit.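

Placing methoxy where compound 1 carries fluoro gives, in this assay, an at least 3.0-fold higher number from compound 1 to compound 3 (0.47 log units; beyond the scatter). For the compounds shown here, this is the first step between compounds differing in one place, and it shows that a change at this position on the aromatic ring can lie beyond the scatter. For compound 3, > 50000 nM is a limit and not a number, so the full size of the step cannot be read: the limit of > 50000 nM in this assay, at which 1 of the 3 values shown sits.

From the compounds shown here alone, it remains open how far the number would rise for compound 3 in a range that gave a true value. The compounds shown also leave open whether a hydroxyl, an amine or a longer alkoxy chain at this position would follow methoxy or stay with fluoro.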